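Urea series: methyl for fluoro on the aryl ring

The source may hold more compounds than are shown below. What is called first, only, known or untested is meant among the compounds shown, and "the series" means these compounds.

Measured so far:
compound 1, `Cc1ccccc1NC(=O)N[C@H](C)c1ccccc1`: 99%
compound 2, `C[C@@H](NC(=O)Nc1ccc(F)cc1F)c1ccccc1`: 93%

In an ADME assay on the whole organism with Oryza sativa as the target, tested at 10 uM (a lower number here means a stronger effect, a higher number a weaker effect of the compound at the concentration tested), compound 1 gives 99%. In this assay compound 2 gives 93%, and the gap between compound 2 and compound 1 lies within the usual scatter, so neither is set apart from the other.

Compound 3, `Cc1cc(F)ccc1NC(=O)N[C@H](C)c1ccccc1`, is not yet measured. It differs from compound 2 by methyl in place of fluoro on an aromatic carbon. Both measured compounds sit close together, so no step beyond the scatter is expected here: the change from compound 2 to compound 3 is estimated at a number 3 percentage points higher from compound 2 to compound 3 (within the scatter). Compound 3 is expected to give 96%, with a range from 86% to 100%.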

Compound 3, a percentage reported as activity, at one concentration (the size of the read-out at that concentration, not a potency): 94%
Beside the measured number, compound 3's estimate is 2 percentage points above it, within the range that was stated.
By their numbers in this assay, from the lowest: compounds 2, 3 and 1 (each within the scatter of the next).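

In this assay, methyl in place of fluoro on an aromatic carbon ortho to a large group gives a number 1 percentage points higher from compound 2 to compound 3 (within the scatter), so this exchange at this position opens no step beyond the scatter. Fluoro in place of hydrogen on an aromatic carbon gives a number 5 percentage points lower from compound 1 to compound 3 (within the scatter), which also stays inside the scatter. No measured information bears on the reason for these small steps.

From the compounds shown here alone, whether an amine or a carboxylic acid on this aromatic carbon would move the number beyond the scatter remains open. So does whether any change elsewhere on the shared core would do so.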